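Shrinking a Ring on a Weak Adenosine Ligand

This account rests on a few compounds, and the source may have more. Where it says the series, first, only, none or still open, it means among the compounds named here.

In an assay on isolated protein for binding affinity to adenosine receptor A1 (Bos taurus) (on this read-out higher numbers stand for weaker inhibition and lower numbers for stronger inhibition), compound 1 `CNc1nc(-c2ccccc2)nc2c1nnn2Cc1ccccc1Cl` gives 191000000 nM, and compound 2 `Clc1ccccc1Cn1nnc2c(NC3CCCC3)nc(-c3ccccc3)nc21` gives 9000000 nM, the lower of the two numbers shown. Among the measured compounds shown here, the single change between them, a 21-fold lower number from compound 1 to compound 2 (1.33 log units; beyond the scatter), is the only measured step so far. Compound 3 `Clc1ccccc1Cn1nnc2c(NC3CCC3)nc(-c3ccccc3)nc21` differs from compound 2 in the same region: cyclobutyl in place of cyclopentyl on a nitrogen on an aromatic ring. For the measured compounds named here, no measured step covers this exact swap; the step from compound 1 to compound 2 is the nearest comparison and hints that a smaller ring may raise the number, though by less than that step. Compound 3 is therefore expected to give 15000000 nM (range 5000000 nM to 60000000 nM), a step of a 1.7-fold higher number from compound 2 to compound 3 (0.22 log units; within the scatter) that is expected to be modest.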

Compound 3, inhibition constant: 24000000 nM
Compound 3: the middle estimate sits 1.6-fold (0.20 log units) below what was measured; measured number inside the range.
By their numbers in this assay, from the lowest: compound 2; then compound 3; then compound 1.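

In this assay, the size of the ring on this nitrogen matters: cyclobutyl in place of cyclopentyl gives a 2.7-fold higher number from compound 2 to compound 3 (0.43 log units; beyond the scatter). The cyclobutyl group still keeps part of the gain over methyl, with an 8.0-fold lower number from compound 1 to compound 3 (0.90 log units; beyond the scatter), so across these three groups the number falls as the group on the nitrogen grows, and no compound shown goes against this. Nothing measured here explains why. On these data alone, whether a larger ring such as cyclohexyl would lower the number further remains open. So does whether an open chain such as isopropyl would match the rings.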